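Quinoline amides: amine substituent and receptor binding

The source may report more compounds than this note shows. Statements on the series, on what has been measured and on what is new or still open speak of the compounds shown alone.

Measured so far, in an assay on isolated protein for displacement of a labelled ligand from melanin-concentrating hormone receptor 1 (Homo sapiens); on this read-out higher numbers stand for weaker inhibition and lower numbers for stronger inhibition:
- compound 1, `O=C(CCc1ccc(C(F)(F)F)cc1)Nc1ccc2nc(N3CC4CC3CN4)ccc2c1`, gives 210 nM
- compound 2, `O=C(CCc1ccc(C(F)(F)F)cc1)Nc1ccc2nc(N3CCC(c4ccccc4)C3)ccc2c1`, gives 25 nM

Among the compounds with values here, compound 2 holds the lowest number of the two; the only other compound, compound 1, sits higher by an 8.4-fold lower number from compound 1 to compound 2 (0.92 log units; beyond the scatter). Within the data shown here, that single step, an exchange of the amine on the aromatic carbon, is the only guide for the next change.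

Compound 3, `CN(C)c1ccc2cc(NC(=O)CCc3ccc(C(F)(F)F)cc3)ccc2n1`, keeps the shared core and the amide and differs from compound 2 by dimethylamino in place of 3-phenylpyrrolidin-1-yl on an aromatic carbon. The step of an 8.4-fold lower number from compound 1 to compound 2 (0.92 log units; beyond the scatter) shows that this position tolerates large swings in this assay, and that the 3-phenylpyrrolidin-1-yl group of compound 2 accounts for the low number seen so far. Removing it in favour of dimethylamino is therefore expected to move compound 3 back upward, by roughly a 16-fold higher number from compound 2 to compound 3 (1.20 log units; beyond the scatter). For compound 3 the estimate in this assay is 400 nM, with a likely range of 100 nM to 2000 nM.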

Compound 3, half-maximal inhibitory concentration: 13 nM
For compound 3 the middle estimate is 31-fold (1.49 log units) above the measured one, and the stated range ends above it.
By their numbers in this assay, from the lowest: compounds 3 and 2 (each within the scatter of the next); then compound 1.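

In this assay, exchanging 3-phenylpyrrolidin-1-yl for dimethylamino gives a 1.9-fold lower number from compound 2 to compound 3 (0.28 log units; within the scatter), so the phenyl-bearing ring is not required for a low number at this position: a group with no ring serves within the scatter. Within the data shown here, the step of a 16-fold lower number from compound 1 to compound 3 (1.21 log units; beyond the scatter) shows that the number does not follow group size across these compounds, since the group of compound 1, intermediate in heavy-atom count, gives the one value set apart from the other two. No measurement at hand accounts for either step.

Open, on these data alone, is whether the higher number of compound 1 goes with the second nitrogen of its group or with its two-ring framework. Diethylamino and piperidin-1-yl at this position would test how far the tolerance extends.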